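A few compounds are considered here, and "the series" means these few. Any claim that something is new, unique, unknown or untested is made for them only; others in the source may bear on it.

Measured compounds:
compound 1, `Cc1ccc(Oc2ccc(C#N)cc2S(=O)(=O)NC(=O)NC(C)(C)C)cc1`, 680 nM
compound 2, `CCCCCNC(=O)NS(=O)(=O)c1cc(C#N)ccc1Oc1ccc(C)cc1`, 630 nM
compound 3, `CCCCCNC(=O)NS(=O)(=O)c1cc(C#N)ccc1Nc1ccccc1C`, 7850 nM

In a functional assay on HEK293 cells for antagonist activity at thromboxane A2 receptor (Homo sapiens), read by fluorescence and calcium flux (on this read-out higher numbers stand for weaker inhibition and lower numbers for stronger inhibition), compound 1 stands second of the three numbers. Its nearest neighbour is compound 2, and the step of a 1.1-fold lower number from compound 1 to compound 2 (0.03 log units; within the scatter) shows that the two lie within the scatter of one another. Compound 3 is far from both, as the step of a 12-fold higher number from compound 2 to compound 3 (1.10 log units; beyond the scatter) shows.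

The unmeasured compound 4, `Cc1ccc(Nc2ccc(C#N)cc2S(=O)(=O)NC(=O)NC(C)(C)C)cc1`, differs from compound 1 in one place: (4-methylphenyl)amino in place of 4-methylphenoxy on an aromatic carbon.

Going by the values given here, one measured step bears on this change. From compound 2 to compound 3 an oxygen-linked aryl group gave way to a nitrogen-linked aryl group, and the step of a 12-fold higher number from compound 2 to compound 3 (1.10 log units; beyond the scatter) was large. Among the compounds with values here, that step also moved the methyl group on the outer ring, so it is not an exact match, but it is the only guide available. The step of a 1.1-fold lower number from compound 1 to compound 2 (0.03 log units; within the scatter) suggests that the tert-butyl group in compound 1 behaves much like the pentyl group of compound 2, so the lesson from compound 3 is expected to carry over.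

Compound 4 is therefore expected to give a higher number in this assay than compound 1, the step of a 7.4-fold higher number from compound 1 to compound 4 (0.87 log units; beyond the scatter) being estimated as large, though the mismatch in the methyl position leaves room for a smaller one. The estimate for compound 4 is 5000 nM, within the range 1500 nM to 15000 nM.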

Compound 4, half-maximal inhibitory concentration: 1040 nM
Estimate against measurement, compound 4: 4.8-fold (0.68 log units) above; measured number below the stated range.
By their numbers in this assay, from the lowest: compounds 2, 1 and 4 (each within the scatter of the next); then compound 3.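

In this assay, putting (4-methylphenyl)amino in place of 4-methylphenoxy on the aromatic carbon para to a cyano group gives a 1.5-fold higher number from compound 1 to compound 4 (0.18 log units; within the scatter), so in this pair the exchange of the oxygen link for an amino link, with its added hydrogen-bond donor, leaves the number within the scatter. Going by these compounds alone, this is the first view of that exchange with the methyl group kept in the same place on the outer ring, whereas a 12-fold higher number from compound 2 to compound 3 (1.10 log units; beyond the scatter) also moved the methyl group, so the large size of that step cannot be taken as the effect of the amino link alone. Nothing given here explains why the two steps differ in size.

The compounds shown leave open whether the large step belongs to the (2-methylphenyl)amino group itself or to its pairing with the pentyl chain, since neither the tert-butyl compound carrying that group nor the pentyl compound carrying (4-methylphenyl)amino stands among them. They also leave open how a sulfur link or a methylene link at this position would read, or an outer ring carrying chlorine in place of the methyl group.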